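Three Cytotoxicity Limits and a Fourth Compound Expected Alongside

The compounds below may be only part of what the source reports. "The series", "measured", "known", "first", "only" and "open" are said of these compounds alone.

Compound 1 `CC(C)N(Cc1cccc(OCCCCCC(=O)O)c1)C(=O)c1ccc(-c2cccc(-c3ccccc3)c2)cc1`: in an ADME assay on HEK293 cells (Homo sapiens) for cytotoxicity, read by CellTiter-Glo and resazurin assay, with a stated time of 72 h (a lower number here means that less compound is needed, a higher number that more compound is needed for the effect), compound 1 gives > 26000 nM, which is a limit of the assay and not a number.
Compound 2 `CC(C)N(Cc1cccc(OCCCCCC(=O)O)c1)C(=O)c1ccc(-c2ccsc2)cc1`: compound 2 gives > 26000 nM, again a limit of the assay.
Compound 3 `CCOc1cccc(-c2ccc(C(=O)N(Cc3cccc(OCCCCCC(=O)O)c3)C(C)C)cc2)c1`: compound 3 gives > 20800 nM, also a limit of the assay.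

Compound 3 therefore stands where its two neighbours stand: at a limit, with no number behind it. Among the three values shown, the limit of > 20800 nM in this assay, at which 1 of the 3 values shown sits, and (the limit of > 26000 nM in this assay, at which 2 of the 3 values shown sit). Every step between the measured compounds is accordingly unreadable: a step that the two limits leave unreadable from compound 1 to compound 2, a step that the two limits leave unreadable from compound 1 to compound 3 and a step that the two limits leave unreadable from compound 2 to compound 3.

Compound 4 `CC(C)N(Cc1cccc(OCCCCCC(=O)O)c1)C(=O)c1ccc(-c2cccc(OC(F)(F)F)c2)cc1` differs from compound 3 by trifluoromethyl in place of ethyl on an oxygen on an aromatic ring. For the measured compounds named here, none of the measured steps bears on this change in a readable way, since each of them runs from one limit to another. The account can thus lean on nothing but the fact that all three measured compounds sit at a limit. From compound 3 to compound 4 the expected step is a step that the limit leaves unreadable from compound 3 to compound 4, that is, none beyond the scatter. For compound 4 the estimate in this assay is 26000 nM, with a range from 9000 nM to 80000 nM, and most probably the assay will again report only a limit.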

Compound 4, half-maximal effective concentration: > 26000 nM
Compound 4: no number, only a limit; the forecaster's own chance of this, stated with the estimate: 85%; the middle value lies on the limit itself.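

Compound 4 gives > 26000 nM, which is a limit of the assay and not a number, so no step can be read between compound 4 and compound 1, compound 2 or compound 3. The compounds shown leave open what concentration, if any, would give a half-maximal effect for each of them in this assay, and whether their differences change it.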